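Chain-end phenyl for propyl: compound 3 expected

This account rests on a few compounds, and the source may have more. Where it says the series, first, only, none or still open, it means among the compounds named here.

Within the data shown here, compound 1 `CCCCCCOc1ccc2c(Cl)ccnc2c1` gives 2380 nM in a functional assay on BGC-823 cells (Homo sapiens) for cytotoxicity, read by MTT assay, with a stated time of 48 h (on this read-out lower numbers stand for stronger inhibition and higher numbers for weaker inhibition), the higher of the two numbers so far; compound 2 `CCCCCCOc1ccc2c(NCCN(C)C)ccnc2c1` gives 1090 nM in this assay. Among the measured compounds shown here, their only step, a 2.2-fold lower number from compound 1 to compound 2 (0.34 log units; beyond the scatter), alters the group on the aromatic carbon and leaves the chain untouched. Compound 3 `Clc1ccnc2cc(OCCCc3ccccc3)ccc12` differs from compound 1 by phenyl in place of propyl on a saturated chain carbon, three bonds along the chain from an oxygen on an aromatic ring. For the measured compounds named here, no measured step touches this chain, so nothing here sets a direction or size for the change; the working assumption is a step that stays within the scatter. For compound 3 the expected value is 2100 nM with a range of 800 nM to 5500 nM. The expected step reads a 1.1-fold lower number from compound 1 to compound 3 (0.05 log units; within the scatter).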

Compound 3, half-maximal inhibitory concentration: 2370 nM
Beside the measured number, compound 3's estimate is 1.1-fold (0.05 log units) below it, within the range that was stated.
By their numbers in this assay, from the lowest: compound 2; then compounds 3 and 1 (each within the scatter of the next).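

The chain position now has its first reading: in this assay, phenyl in place of propyl on a saturated chain carbon, three bonds along the chain from an oxygen on an aromatic ring, gives a 1.0-fold lower number from compound 1 to compound 3 (0.00 log units; within the scatter). With chloro held constant, this position therefore accepts the phenyl-ended chain of compound 3 with no difference beyond the scatter. No available evidence explains this result.

Going by these compounds, whether an amine or a carboxylic acid at the chain end would also stay within the scatter remains open. So does whether the phenyl-ended chain gives the same result with (2-(dimethylamino)ethyl)amino in place of chloro.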